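The source may report more compounds than this note shows. Statements on the series, on what has been measured and on what is new or still open speak of the compounds shown alone.

Compound 1 `c1ccc(CCOc2ccc3c(c2)OCCO3)cc1` gives 48 nM in an assay on isolated protein for inhibition of Amine oxidase [flavin-containing] B (Homo sapiens), read by fluorescence and spectrophotometry; a higher number here means a weaker inhibitor, a lower number a stronger inhibitor. Compound 2 `c1ccc(OCCOc2ccc3c(c2)OCCO3)cc1` gives 109 nM in this assay, and compound 3 `Clc1ccc(OCCOc2ccc3c(c2)OCCO3)cc1` gives 348 nM in this assay. Compound 3 therefore stands at the highest of the three numbers: its gap to compound 2 and its gap to compound 1 both lie beyond the scatter. For the measured compounds named here, the one measured step that changes a single place is a 3.2-fold higher number from compound 2 to compound 3 (0.50 log units; beyond the scatter). Compound 4 `Brc1ccc(OCCOc2ccc3c(c2)OCCO3)cc1` differs from compound 3 by bromo in place of chloro on an aromatic carbon. Going by the values given here, no measured step exchanges one halogen for another; the only single-place step, from compound 2 to compound 3, adds a chloro where there was hydrogen, so it bears on the present change only loosely. Among the compounds with values here, with compound 3 at 348 nM as the anchor and no measured step that speaks directly to a bromo for chloro swap, compound 4 is expected to move little, by no more than the scatter, in this assay. The estimated step is a 1.1-fold higher number from compound 3 to compound 4 (0.06 log units; within the scatter). Compound 4 is thus estimated at 400 nM, with a range from 150 nM to 1100 nM.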

Compound 4, half-maximal inhibitory concentration: 941 nM
For compound 4 the middle estimate is 2.4-fold (0.37 log units) below the measured one; the measured number falls inside the stated range.
By their numbers in this assay, from the lowest: compound 1; then compound 2; then compound 3; then compound 4.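

In this assay, the identity of the halogen on this aromatic carbon, para to a large group, matters as well as its presence: bromo in place of chloro gives a 2.7-fold higher number from compound 3 to compound 4 (0.43 log units; beyond the scatter). Bromo in place of hydrogen gives an 8.6-fold higher number from compound 2 to compound 4 (0.94 log units; beyond the scatter), a larger step than chloro in place of hydrogen, a 3.2-fold higher number from compound 2 to compound 3 (0.50 log units; beyond the scatter), so among these three compounds the number rises from hydrogen to chloro to bromo at this one position. Nothing given here accounts for this rise.

The compounds shown leave open whether fluoro, a methoxy group, an amine or a carboxylic acid at this position would continue or break that order. They also leave open whether the same halogen steps would hold on compound 1, whose chain differs from that of compound 2.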